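Pentyl in place of 4-chlorophenyl: compound 4 awaits measurement

The source may report more compounds than this note shows. Statements on the series, on what has been measured and on what is new or still open speak of the compounds shown alone.

Of the compounds shown here, three have been measured so far. In a functional assay on HepG2 cells (Homo sapiens) for antiproliferative activity, read by MTT assay (on this read-out lower numbers stand for stronger inhibition and higher numbers for weaker inhibition), compound 2 (`CC1(C)CCc2c(ccc(C(=O)/C=C/c3ccc(OCc4cn(-c5ccc(Cl)cc5)nn4)cc3)c2O)O1`) gives 102000 nM. Compound 3 (`CCCCCn1cc(COc2ccc(/C=C/C(=O)c3cc4c(cc3O)OC(C)(C)CC4)cc2)nn1`) gives 95800 nM, which lies within the scatter of the number for compound 2. Compound 1 (`CC(=O)c1ccc(-n2cc(COc3ccc(/C=C/C(=O)c4cc5c(cc4O)OC(C)(C)CC5)cc3)nn2)cc1`) is reported only as "not active" (no number reported), without a number, so compound 2 can be set against just one other figure.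

Compound 4 (`CCCCCn1cc(COc2ccc(/C=C/C(=O)c3ccc4c(c3O)CCC(C)(C)O4)cc2)nn1`) has not yet been measured. Its change from compound 2 is pentyl in place of 4-chlorophenyl on an aromatic nitrogen, with pentyl in place of 4-chlorophenyl on an aromatic nitrogen. Going by the values given here, no measured pair shows this change on its own, so the expectation rests on little. Compound 3, which also carries pentyl, gives 95800 nM, so no large shift is expected in this assay. The estimated change is a 1.1-fold lower number from compound 2 to compound 4 (0.05 log units; within the scatter), and it is not expected to go beyond the scatter. For compound 4 the expected value is 90000 nM, with an estimated range from 40000 nM to 200000 nM.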

Compound 4, half-maximal inhibitory concentration: 9820 nM
Beside the measured number, compound 4's estimate is 9.2-fold (0.96 log units) above it; the whole stated range lies above it.
By their numbers in this assay, from the lowest: compound 4; then compounds 3 and 2 (each within the scatter of the next).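

Pentyl in place of 4-chlorophenyl on the aromatic nitrogen gives a 10-fold lower number from compound 2 to compound 4 (1.02 log units; beyond the scatter) in this assay and is the first single change that can be read at this position. It shows that the group on this nitrogen matters on the core of compound 2, which the close values of compound 2 and compound 3 could not show, as those two compounds differ in more than one place. No measured evidence accounts for the size of this step.

Compound 3 carries the same pentyl on a differently arranged core and gives 95800 nM and so the compounds shown do not settle whether the step would hold on another core. They also leave open how a shorter chain such as propyl, a longer chain such as octyl or a benzyl group would fare on this nitrogen.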